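Fluoro in Place of Hydrogen on Compound 1

The source may hold more compounds than are shown below. What is called first, only, known or untested is meant among the compounds shown, and "the series" means these compounds.

Compound 1 `O=C(Nc1ccccn1)c1cc2n(n1)CCCC2` is the reference point. Going by the values given here, in a functional assay on HEK293 cells for negative allosteric modulation of metabotropic glutamate receptor 5 (Rattus norvegicus), read by FLIPR and calcium flux, with a stated time of 170 s (on this read-out lower numbers stand for stronger inhibition and higher numbers for weaker inhibition), compound 1 gives 364 nM, the only outright number among the three results in hand. Compound 2 `Nc1cccnc1NC(=O)c1cc2n(n1)CCCC2` reaches only the limit of the assay, > 10000 nM in this assay. Compound 3 `O=C(Nc1ncccc1O)c1cc2n(n1)CCCC2` likewise stops at the limit > 10000 nM in this assay. The two measured steps were an at least 27-fold higher number from compound 1 to compound 2 (1.43 log units; beyond the scatter) and an at least 27-fold higher number from compound 1 to compound 3 (1.43 log units; beyond the scatter), each ending at the limit of > 10000 nM in this assay, at which 2 of the 3 values shown sit. Between compound 2 and compound 3 the step is a step that the two limits leave unreadable from compound 2 to compound 3.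

Compound 4 `O=C(Nc1cccc(F)n1)c1cc2n(n1)CCCC2` differs from compound 1 by fluoro in place of hydrogen on an aromatic carbon. The two measured steps bear on this change only at a distance: each put amino or hydroxy onto the same ring, not fluoro, and each was large. Fluoro is a different entering group, so those steps set no firm expectation of a similar collapse, while leaving open that a substituent on this ring weakens inhibition. The estimate for compound 4 is a step of a 1.5-fold higher number from compound 1 to compound 4 (0.18 log units; within the scatter) in this assay, a mild rise that may fall within the scatter. Compound 4 is expected to come in at 550 nM, within a range of 150 nM to 2500 nM.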

Compound 4, half-maximal inhibitory concentration: 4740 nM
Beside the measured number, compound 4's estimate is 8.6-fold (0.94 log units) below it; the measured number lies above the stated range.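

A single fluoro group in place of hydrogen is enough to weaken inhibition sharply: in this assay the change gives a 13-fold higher number from compound 1 to compound 4 (1.11 log units; beyond the scatter) and so lies well beyond the scatter. The earlier compounds shown here showed losses with amino and hydroxy only, and those losses ended at limits, whereas here a substituent on the same ring has a cost of readable size, for a group that counts no hydrogen-bond donors or acceptors and sits on an aromatic carbon next to the ring nitrogen. Compound 4 keeps an outright number, so fluoro at this place does not reach the limit held by compounds 2 and 3: the limit of > 10000 nM in this assay, at which 2 of the 4 values shown sit.

The compounds shown leave open whether this loss belongs to fluoro itself or would also follow a methyl group, a chlorine atom or a methoxy group at the same place, and whether fluoro on another carbon of the ring would cost as much. The step between compound 2 and compound 3 cannot be read, so amino and hydroxy remain unranked against each other.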